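From methoxy to phenoxy: compound 3 and compound 4

The compounds below may be only part of what the source reports. "The series", "measured", "known", "first", "only" and "open" are said of these compounds alone.

- Compound 1 `CCOC(=O)c1c(-c2cccc(Oc3ccccc3)c2)[nH]c2cc(Cl)c(Cl)cc2c1=O` gives > 21500 nM (a limit)
- Compound 2 `CCOC(=O)c1c(-c2cccc(-c3ccccc3)c2)[nH]c2cc(OC)c(Cl)cc2c1=O` gives > 21500 nM (a limit)
- Compound 3 `CCOC(=O)c1c(-c2cccc(OC)c2)[nH]c2cc(OC)c(Cl)cc2c1=O` gives > 21500 nM (a limit)

All three entries come from an ADME assay on HepG2 cells (Homo sapiens) for cytotoxicity, read by luminescence, with a stated time of 72 h (on this read-out higher numbers stand for an effect only at larger amounts of compound and lower numbers for an effect already at smaller amounts), and none of them is a number. Compound 3 therefore stands only at a limit, > 21500 nM, like the other two compounds. Compound 4 `CCOC(=O)c1c(-c2cccc(Oc3ccccc3)c2)[nH]c2cc(OC)c(Cl)cc2c1=O` has not yet been measured. It differs from compound 3 by phenyl in place of methyl on an oxygen on an aromatic ring, which is phenyl in place of methyl on an oxygen on an aromatic ring, or methoxy to phenoxy. For the measured compounds named here, the one measured step that bears on this change is a step that the two limits leave unreadable from compound 2 to compound 3, so compound 3 offers no readable size to carry over. No step beyond the scatter is expected in this assay because of the limit of > 21500 nM in this assay, at which 3 of the 3 values shown sit, and another limit is the most likely report. The expected size is a step that the limit leaves unreadable from compound 3 to compound 4, and this remains an estimate. For compound 4 the estimated value is 22000 nM, with an expected range from 10000 nM to 40000 nM.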

Compound 4, half-maximal effective concentration: > 21500 nM
Compound 4 was reported as a limit; the forecaster's own chance of this, stated with the estimate: 85%; the middle value is on the limit's open side.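

Compound 4, like compound 1, compound 2 and compound 3, is reported only as a limit, so no step among these compounds can be read in this assay: the limit of > 21500 nM in this assay, at which 4 of the 4 values shown sit.

The compounds shown leave open how large any difference between them is and at what concentration any of them reaches its half-maximal effect.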